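This account rests on a few compounds, and the source may have more. Where it says the series, first, only, none or still open, it means among the compounds named here.

Measured compounds:
compound 1, `FC(F)(F)Oc1ccc(-c2ccc(-c3ccc(-c4nc5ccccc5[nH]4)cc3)cc2)cc1`, 100000 nM;
compound 2, `Oc1ccc(-c2ccc(-c3ccc(-c4nc5ccccc5[nH]4)cc3)cc2)cc1`, 100000 nM;
compound 3, `Cc1ccc2[nH]c(-c3ccc(-c4ccc(-c5ccc(OC(F)(F)F)cc5)cc4)cc3)nc2c1`, 2410 nM.

In a functional assay on ZR-75-1 cells (Homo sapiens) for inhibition, read by sulforhodamine B assay (a higher number here means a weaker inhibitor of growth, a lower number a stronger inhibitor of growth), compound 1 and compound 2 give the same number: the change hydrogen in place of trifluoromethyl on an oxygen on an aromatic ring produced no change at the digits printed from compound 1 to compound 2 (within the scatter). Compound 3 differs from compound 1 by methyl in place of hydrogen on an aromatic carbon, and that step gave a 41-fold lower number from compound 1 to compound 3 (1.62 log units; beyond the scatter), leaving compound 3 with the lowest of the three numbers. Compound 4, `Cc1ccc2[nH]c(-c3ccc(-c4ccc(-c5ccc(O)cc5)cc4)cc3)nc2c1`, is not yet measured. It differs from compound 3 by hydrogen in place of trifluoromethyl on an oxygen on an aromatic ring, the same change as that from compound 1 to compound 2. Since that earlier change left the number unaltered, compound 4 is expected to sit close to compound 3, with a step of a 1.5-fold higher number from compound 3 to compound 4 (0.16 log units; within the scatter) in this assay, allowing some widening for the uncertainty of a single precedent. Compound 4 is therefore estimated at 3500 nM, between 1000 nM and 15000 nM.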

Compound 4, concentration for 50% growth inhibition: 18200 nM
For compound 4 the middle estimate is 5.2-fold (0.72 log units) below the measured one; the measured number lies above the stated range.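

In this assay, hydrogen in place of trifluoromethyl on the oxygen gave a 7.6-fold higher number from compound 3 to compound 4 (0.88 log units; beyond the scatter), so this change did not carry over at the same size from one core to the other: the same change on two cores in this assay, no change at the digits printed (within the scatter) from compound 1 to compound 2 and a 7.6-fold higher number (0.88 log units; beyond the scatter) from compound 3 to compound 4, 7.6-fold (0.88 log units) apart, beyond the scatter of two such steps. Methyl in place of hydrogen on the aromatic carbon gave a 5.5-fold lower number from compound 2 to compound 4 (0.74 log units; beyond the scatter), which kept the direction of the earlier step but not its size: the same change on two cores in this assay, a 41-fold lower number (1.62 log units; beyond the scatter) from compound 1 to compound 3 and a 5.5-fold lower number (0.74 log units; beyond the scatter) from compound 2 to compound 4, 7.6-fold (0.88 log units) apart, beyond the scatter of two such steps. These four compounds show that the two changes do not add independently here, but they do not show why, or how either change would behave on a further core.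

Going by these compounds, it remains open how an amine or a longer chain on that oxygen would compare. The same holds for chlorine or a carboxylic acid in place of the methyl.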